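A Fluorophenyl Swap on the Sulfonyl Group

The source may hold more compounds than are shown below. What is called first, only, known or untested is meant among the compounds shown, and "the series" means these compounds.

Compound 1 `Cc1ccccc1S(=O)(=O)c1ccc(CNC(=O)c2cc3cnccc3[nH]2)cc1` stands at the lowest of the two numbers at hand. In an assay for inhibition of Nicotinamide phosphoribosyltransferase (Homo sapiens), read by mass spectrometry, with stated times of 15 min and 30 min (on this read-out higher numbers stand for weaker inhibition and lower numbers for stronger inhibition), compound 1 gives 12 nM. Compound 2 `O=C(NCc1ccc(S(=O)(=O)c2ccccc2)cc1)c1nc2cnccc2[nH]1` has a different core and a different group on the sulfonyl sulfur; in this assay compound 2 gives 7100 nM, a much higher number, and the gap between the two lies well beyond the scatter. Among the compounds with values here, no pair of measured compounds differs in only one place, so no measured step guides the change considered here.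

Compound 3 `O=C(NCc1ccc(S(=O)(=O)c2cccc(F)c2)cc1)c1cc2cnccc2[nH]1` keeps the core of compound 1 and differs from it in one place: 3-fluorophenyl in place of 2-methylphenyl on a sulfonyl sulfur. Each group is a single six-membered aromatic ring of carbon only. Within the data shown here, with no measured precedent, the step from compound 1 to compound 3 is expected to be small, a 1.7-fold higher number from compound 1 to compound 3 (0.22 log units; within the scatter), toward a slightly higher number or none beyond the scatter. Compound 3 is estimated at 20 nM, between 6 nM and 70 nM.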

Compound 3, half-maximal inhibitory concentration: 5 nM
For compound 3 the middle estimate is 4.0-fold (0.60 log units) above the measured one, outside the stated range (below it).
By their numbers in this assay, from the lowest: compound 3; then compound 1; then compound 2.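

With the core held fixed, 3-fluorophenyl in place of 2-methylphenyl on the sulfonyl sulfur gives a 2.4-fold lower number from compound 1 to compound 3 (0.38 log units; beyond the scatter) in this assay. Within the data shown here, this is the first measured change at this position alone, and it shows that the number here responds to a modest degree when one single carbon-only aromatic ring replaces another of the same heavy-atom count. Nothing measured here accounts for the direction or size of this step.

The compounds shown leave open how much of the step comes from the methyl group leaving and how much from the fluorine entering, as both happen in this one change. Also open, going by these compounds, is whether something other than a single aromatic ring on the sulfonyl sulfur, such as a morpholine or a short alkyl amine, would keep the number this low.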